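A few compounds are considered here, and "the series" means these few. Any claim that something is new, unique, unknown or untested is made for them only; others in the source may bear on it.

Measured compounds:
- Compound 1, `C#CCCOC(=O)c1ccc(C(CC)(CC)c2ccc(OCCC(O)(CC)CC)c(C)c2)n1CC`. In a functional assay on PC-3 cells (Homo sapiens) for antiproliferative activity, read by MTT assay, with a stated time of 48 h (a higher number here means a weaker inhibitor, a lower number a stronger inhibitor), compound 1 gives > 50000 nM, which is a limit of the assay and not a number.
- Compound 2, `CCn1c(C(=O)N(C)CC(=O)O)ccc1C(CC)(CC)c1ccc(OCCC(O)(CC)CC)c(C)c1`. In this assay compound 2 gives 2250 nM.

Among the measured compounds shown here, compound 1 therefore stands at the limit of > 50000 nM in this assay, at which 1 of the 2 values shown sits; it is the one compound of the two for which no number is known. Compound 3 is `CCC(C)C(CO)NC(=O)c1ccc(C(CC)(CC)c2ccc(OCCC(O)(CC)CC)c(C)c2)n1CC`. It differs from compound 1 at a single place: (1-(hydroxymethyl)-2-methylbutyl)amino in place of (but-3-yn-1-yl)oxy on a carbonyl carbon. In both the measured pair and this new pair, the group attached through oxygen to the carbonyl carbon gives way to a group attached through nitrogen. For the measured compounds named here, the one measured step that bears on this change is an at least 22-fold lower number from compound 1 to compound 2 (1.34 log units; beyond the scatter), a large move toward stronger inhibition. Since the change from compound 1 to compound 3 touches the same carbonyl carbon in the same manner, the expected step in this assay is likewise a clear drop, an at least 14-fold lower number from compound 1 to compound 3 (1.15 log units; beyond the scatter), though the (1-(hydroxymethyl)-2-methylbutyl)amino group is not the same as the (carboxymethyl)(methyl)amino group, so the size is uncertain. For compound 3 the estimated value in this assay is 3500 nM, with an expected range from 800 nM to 25000 nM.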

Compound 3, half-maximal inhibitory concentration: 28400 nM
Estimate against measurement, compound 3: 8.1-fold (0.91 log units) below; the whole stated range lies below it.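

Replacing the group attached through oxygen with one attached through nitrogen does not by itself bring the large gain seen earlier: in this assay there is an at least 1.7-fold lower number from compound 1 to compound 3 (0.24 log units; that floor lies within the scatter). The two groups attached through nitrogen also differ sharply on the same carbonyl carbon, with a 13-fold higher number from compound 2 to compound 3 (1.10 log units; beyond the scatter), so at this position what the nitrogen carries matters and not only the presence of the nitrogen. The first of these steps gives only a floor, and its true size stays unknown, as the figure for compound 1 is a limit of the assay and not a number: the limit of > 50000 nM in this assay, at which 1 of the 3 values shown sits.

The compounds shown leave open which feature of the (carboxymethyl)(methyl)amino group goes with the stronger inhibition of compound 2, whether its carboxylic acid, the methyl on its nitrogen or both, and whether the hydroxymethyl or the branched chain of the (1-(hydroxymethyl)-2-methylbutyl)amino group goes with the weaker inhibition of compound 3. A plain methylamino group or a (2-hydroxyethyl)amino group on the same carbonyl carbon would begin to separate these features.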